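This account rests on a few compounds, and the source may have more. Where it says the series, first, only, none or still open, it means among the compounds named here.

Working notes on the series. The three measured compounds share one core and differ at two places: the ring attached to an aromatic carbon, and the chain carried on the acrylamide. Compound 1 `CCC/C=C/C(=O)Nc1cc2c(N3CCc4ccccc43)ncnc2cc1O[C@@H]1CCOC1` gives 9230 nM in a functional assay on PC-3 cells (Homo sapiens) for antiproliferative activity, read by MTT assay, with a stated time of 72 h; a lower number here means a stronger inhibitor, a higher number a weaker inhibitor. Compound 2 `CC(C)/C=C/C(=O)Nc1cc2c(N3CCCc4ccccc43)ncnc2cc1O[C@@H]1CCOC1` gives 8510 nM in this assay. Compound 3 `CCC/C=C/C(=O)Nc1cc2c(N3CCCc4ccccc43)ncnc2cc1O[C@@H]1CCOC1` gives 11800 nM in this assay. Compound 3 carries the highest of the three numbers, but both neighbours sit close: a 1.3-fold higher number from compound 1 to compound 3 (0.11 log units; within the scatter) and a 1.4-fold higher number from compound 2 to compound 3 (0.14 log units; within the scatter), so the three are not separated beyond the scatter and no order can be read from them.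

Compound 4 `CN(C)C/C=C/C(=O)Nc1cc2c(N3CCCc4ccccc43)ncnc2cc1O[C@@H]1CCOC1` is the next member. The change from compound 3 is dimethylamino in place of ethyl on a saturated chain carbon bound to a double-bonded chain carbon. Within the data shown here, no measured step covers this exchange. Among the measured compounds shown here, the only step touching the chain, from compound 2 to compound 3, concerns propyl against isopropyl on a double-bonded chain carbon and stayed within the scatter; the step from compound 1 to compound 3 concerns the ring and does not bear on the chain. On this basis no step beyond the scatter is expected in this assay, in either direction, and the step from compound 3 to compound 4 is estimated at a 1.2-fold lower number from compound 3 to compound 4 (0.07 log units; within the scatter). Compound 4 is therefore expected to give about 10000 nM, within 3000 nM to 35000 nM.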

Compound 4, half-maximal inhibitory concentration: 4170 nM
Compound 4: the middle estimate sits 2.4-fold (0.38 log units) above what was measured; the range from low to high includes it.
By their numbers in this assay, from the lowest: compound 4; then compounds 2, 1 and 3 (each within the scatter of the next).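

In this assay, the chain carried on the acrylamide now moves the number beyond the scatter, which the exchange of propyl and isopropyl did not do. Dimethylamino in place of ethyl on a saturated chain carbon bound to a double-bonded chain carbon gives a 2.8-fold lower number from compound 3 to compound 4 (0.45 log units; beyond the scatter), and set against the isopropyl chain, the chain ending in dimethylamino gives a 2.0-fold lower number from compound 2 to compound 4 (0.31 log units; beyond the scatter), so compound 4 stands apart from both chains without nitrogen, though both steps are modest. Nothing at hand bears on what lies behind these steps.

From the compounds shown here alone, it stays open whether the change is tied to dimethylamino itself or would also appear with another group at this place, such as diethylamino, a carboxylic acid or a longer chain ending in an amine. Going by these compounds, it also stays open whether the same exchange would carry over to the 2,3-dihydro-1H-indol-1-yl group of compound 1, which appears here only with the pent-1-en-1-yl chain.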